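A few compounds are considered here, and "the series" means these few. Any claim that something is new, unique, unknown or untested is made for them only; others in the source may bear on it.

Within the data shown here, compound 3 `COc1cc2cc(Oc3ccc(NC(=O)Nc4cccc(C(F)(F)F)c4)cc3)c(C)nc2cc1OC` gives 8.32% in a functional assay on OVCAR-8 cells (Homo sapiens) for inhibition, read by sulforhodamine B assay, with a stated time of 48 h, tested at 10 uM (a lower number here means a stronger effect, a higher number a weaker effect of the compound at the concentration tested), the lowest of the three numbers measured so far. Compound 1 `COc1cc2cc(Oc3ccc(NC(=O)Nc4ccc(C)cc4)cc3)c(C)nc2cc1OC` gives 87.4% and compound 2 `COc1cc2cc(Oc3ccc(NC(=O)Nc4ccc(C(F)(F)F)cc4)cc3)c(C)nc2cc1OC` gives 37.8%. The steps of a number 49.6 percentage points lower from compound 1 to compound 2 (beyond the scatter), a number 79.1 percentage points lower from compound 1 to compound 3 (beyond the scatter) and a number 29.5 percentage points lower from compound 2 to compound 3 (beyond the scatter) all lie beyond the scatter and show that the substituent pattern of the phenyl on the amide-type nitrogen decides the read-out in this series. Compound 4 `COc1cc2cc(Oc3ccc(NC(=O)Nc4ccc(Cl)c(C(F)(F)F)c4)cc3)c(C)nc2cc1OC` differs from compound 3 by chloro in place of hydrogen on an aromatic carbon, placed on the same phenyl, ortho to the trifluoromethyl group and para to a large group. Among the measured compounds shown here, no measured step adds a chloro, so the three steps bear only indirectly, as a sign that this ring is sensitive to substitution. Compound 3 already stands close to the floor of the read-out, leaving little room for a further fall, so the step of a number 2.3 percentage points lower from compound 3 to compound 4 (within the scatter) is expected to be small or not beyond the scatter. Compound 4 is therefore expected near 6%, within 0% to 22%.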

Compound 4, a percentage reported as activity, at one concentration (the size of the read-out at that concentration, not a potency): 7.34%
The estimate for compound 4 lay 1.3 percentage points below the measured number; the range from low to high includes it.
By their numbers in this assay, from the lowest: compounds 4 and 3 (each within the scatter of the next); then compound 2; then compound 1.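

In this assay, chloro on this aromatic carbon, ortho to the trifluoromethyl group and para to a large group, leaves the read-out within the scatter: a number 1 percentage points lower from compound 3 to compound 4 (within the scatter). This position therefore tolerates chloro, at least at the single concentration tested, and the 4-chloro-3-(trifluoromethyl)phenyl group keeps clear separation from the two other aryl ureas: a number 30.5 percentage points lower from compound 2 to compound 4 (beyond the scatter) and a number 80.1 percentage points lower from compound 1 to compound 4 (beyond the scatter). Nothing available explains why the chloro leaves the read-out unmoved.

Compound 3 and compound 4 both sit near the floor of the read-out, so a single-concentration percentage cannot show whether their potencies differ. On these data alone, whether a fluoro, a methoxy or an amine on the same carbon would hold the read-out this low remains open.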